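Methylating the Aniline Nitrogen of a Bile Acid Receptor Agonist

The source may hold more compounds than are shown below. What is called first, only, known or untested is meant among the compounds shown, and "the series" means these compounds.

Compound 1 `CN(Cc1cccc(C(=O)O)c1)c1ccc(OCc2c(-c3c(Cl)cccc3Cl)noc2C2CC2)nc1C(F)(F)F`: 3 nM
Compound 2 `CC(Nc1ccc(C(=O)O)cc1)c1ccc(OCc2c(-c3c(Cl)cccc3Cl)noc2C2CC2)nc1C(F)(F)F`: 101 nM

For the measured compounds named here, in an assay on isolated protein for agonist activity at Bile acid receptor (Homo sapiens), read by FRET (a higher number here means that more compound is needed for the effect, a lower number that less compound is needed), compound 1 gives 3 nM, while compound 2 gives 101 nM, the highest of the two numbers; the single measured step, a 34-fold higher number from compound 1 to compound 2 (1.53 log units; beyond the scatter), is large. Compound 3 `CC(c1ccc(OCc2c(-c3c(Cl)cccc3Cl)noc2C2CC2)nc1C(F)(F)F)N(C)c1ccc(C(=O)O)cc1` differs from compound 2 by methyl in place of hydrogen on a nitrogen on an aromatic ring. Going by the values given here, only that one step bears on this change, and it bundles the methylation with other alterations, so its weight cannot be isolated. A moderate decrease is nonetheless expected, a 2.5-fold lower number from compound 2 to compound 3 (0.40 log units; beyond the scatter), because compound 1 with its methyl on nitrogen gives 3 nM. Compound 3 is estimated at 40 nM, with a range from 10 nM to 160 nM.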

Compound 3, half-maximal effective concentration: 179 nM
Compound 3: middle estimate off by 4.5-fold (0.65 log units), on the low side; the measured number lies above the stated range.
By their numbers in this assay, from the lowest: compound 1; then compounds 2 and 3 (each within the scatter of the next).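

In this assay, methyl in place of hydrogen on this nitrogen gives a 1.8-fold higher number from compound 2 to compound 3 (0.25 log units; within the scatter), so compound 2 and compound 3 cannot be told apart. At this position, in this setting, the added methyl alone therefore brings no measurable change in the number. Nothing measured here offers a reason for this result. The compounds shown leave open whether an ethyl group or a longer chain on this nitrogen would also leave the number unchanged. As far as these compounds go, whether an acetyl group there would do the same also remains open.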